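This account rests on a few compounds, and the source may have more. Where it says the series, first, only, none or still open, it means among the compounds named here.

Working notes on the series. Of the compounds shown here, three have been measured in a functional assay on HT-29 cells (Homo sapiens) for cytotoxicity, read by MTT assay, with a stated time of 72 h; on this read-out lower numbers stand for stronger inhibition of growth and higher numbers for weaker inhibition of growth. Compound 1 `CS/C(=N\C(=O)c1sccc1Cl)NC(=O)c1sccc1Cl` gives 35600 nM in this assay. Compound 2 `O=C(/N=C(/NC(=O)c1cc(-c2ccccc2)nc2ccccc12)[Se]Cc1ccccc1)c1cc(-c2ccccc2)nc2ccccc12` gives 6070 nM in this assay. Compound 3 `O=C(/N=C(/NC(=O)c1cccs1)[Se]Cc1ccccc1)c1cccs1` gives 55100 nM in this assay. On these numbers compound 2 stands lowest of the three; compound 1 is the nearest to it and compound 3 the furthest, and both of those gaps lie beyond the usual scatter of this assay.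

The unmeasured compound 4 `CS/C(=N\C(=O)c1cc(-c2ccccc2)nc2ccccc12)NC(=O)c1cc(-c2ccccc2)nc2ccccc12` keeps the two acyl parts of compound 2 and changes only the group on the central carbon: a group of 2 heavy atoms (1 carbon, 1 sulfur; no ring) in place of a group of 8 heavy atoms (7 carbon, 1 selenium; one six-membered aromatic ring of carbon only), on a carbon with a double bond to nitrogen. Among the measured compounds shown here, no measured pair differs in that one place alone, so the size of the step can only be guessed from what compound 1 and compound 3 show, which share neither core with compound 2 and differ from each other in more than this group.

Compound 4 is expected to fall near compound 2 or somewhat higher in this assay, with the step of a 1.6-fold higher number from compound 2 to compound 4 (0.22 log units; within the scatter) in the direction of weaker growth inhibition, because compound 1 with the methylsulfanyl group gives 35600 nM against the higher number of compound 3. Compound 4 is therefore estimated at 10000 nM in this assay, with a range from 3000 nM to 35000 nM.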

Compound 4, concentration for 50% growth inhibition: 23700 nM
Compound 4: the middle estimate sits 2.4-fold (0.37 log units) below what was measured; the range from low to high includes it.
By their numbers in this assay, from the lowest: compound 2; then compounds 4, 1 and 3 (each within the scatter of the next, the first and the last beyond it).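

Among the compounds shown here, with the two acyl parts held fixed, the change at the carbon with a double bond to nitrogen can now be read directly for the first time. In this assay the move from the group of 8 heavy atoms, which carries selenium and a six-membered aromatic ring, to methylsulfanyl gives a 3.9-fold higher number from compound 2 to compound 4 (0.59 log units; beyond the scatter) and so moves the read-out towards weaker inhibition of growth. This place on the shared core therefore does not tolerate the exchange without a change in the read-out, though this rests on a single pair, and nothing at hand gives a reason for the step.

Going by these compounds, the step combines the exchange of selenium for sulfur with the loss of the ring, so the share of each remains open; a methylselanyl group or a benzylsulfanyl group on the same carbon of the shared core would separate the two. Also open, on these data alone, is whether the step keeps its size and direction with other acyl parts, such as those of compound 1 and compound 3, whose own pair differs in more than one place.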